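Chloro for hydrogen at two places in one series

The compounds below may be only part of what the source reports. "The series", "measured", "known", "first", "only" and "open" are said of these compounds alone.

Compound 1 `O=C1Nc2ccc(Cl)cc2/C1=N/NC(=S)N1CCN(c2ccccc2)CC1` and compound 2 `O=C1Nc2ccc(Cl)cc2/C1=N/NC(=S)N1CCN(c2ccc(Cl)cc2)CC1` share a core and carry a chloro on it; they differ on the outer ring. In a functional assay on A549 cells (Homo sapiens) for inhibition, read by MTT assay, with a stated time of 72 h (on this read-out lower numbers stand for stronger inhibition and higher numbers for weaker inhibition), compound 1 gives 7340 nM. In this assay compound 2 gives 8180 nM. The step of a 1.1-fold higher number from compound 1 to compound 2 (0.05 log units; within the scatter) is the measured reference for the change (chloro in place of hydrogen on an aromatic carbon).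

Compound 3 `O=C1Nc2ccccc2/C1=N/NC(=S)Nc1ccccc1` has no chloro on the core and an anilino group in place of the piperazine. In this assay compound 3 reaches only a limit, > 100000 nM, which is the limit (the limit of > 100000 nM in this assay, at which 1 of the 3 values shown sits). How the core of compound 3 differs from that of compound 1 is not broken down here.

Compound 4 `O=C1Nc2ccc(Cl)cc2/C1=N/NC(=S)Nc1ccccc1` is to be measured in this assay. It differs from compound 3 by chloro in place of hydrogen on an aromatic carbon. This is the same kind of change as that from compound 1 to compound 2, not the same: there the chloro sits on a six-membered aromatic ring of carbon only, para to a large group; here it sits on a ring that is part of a fused or bridged system of two rings, meta to a fused ring and para to a fused ring. For the measured compounds named here, the only measured step of this kind, a 1.1-fold higher number from compound 1 to compound 2 (0.05 log units; within the scatter), is small. The value of compound 3 is a limit, so the base of the step is itself uncertain. Compound 4 is expected to sit near the limit as well, with an estimated step of an at least 1.2-fold lower number from compound 3 to compound 4 (0.09 log units; that floor lies within the scatter), resting on the small size of the step from compound 1 to compound 2. The estimate for compound 4 is 80000 nM, between 20000 nM and 200000 nM.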

Compound 4, half-maximal inhibitory concentration: 33100 nM
Estimate against measurement, compound 4: 2.4-fold (0.38 log units) above; the measured number falls inside the stated range.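

In this assay, chloro in place of hydrogen on an aromatic carbon gives an at least 3.0-fold lower number from compound 3 to compound 4 (0.48 log units; beyond the scatter), so in these two cases the change does not carry from one core to the other at one size: the same change on two cores in this assay, a 1.1-fold higher number (0.05 log units; within the scatter) from compound 1 to compound 2 and an at least 3.0-fold lower number (0.48 log units; beyond the scatter) from compound 3 to compound 4, at least 3.3-fold (0.52 log units) apart, beyond the scatter of two such steps

Going by these compounds, the value of compound 3, > 100000 nM, is a limit, so the new step is only a floor and its full size remains unknown. The two steps also differ in the place of the chloro, on the outer ring in one and on the ring of the fused system in the other, and in the group around it, piperazine in one and anilino in the other, so they do not show which of these differences goes with the gap, and two steps give no rule for the series.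

Open, on these data alone, is whether chloro in place of hydrogen at the fused-system position gives a step of similar size when the piperazine is present, and whether chloro on the outer ring of the anilino compounds follows the step seen with the piperazine compounds. Also open, as far as these compounds go, is how bromo, methoxy or nitrile would read at the place now held by chloro in compound 4.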